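Aryl ether variation on a shared sugar core: cytotoxicity notes

The source may report more compounds than this note shows. Statements on the series, on what has been measured and on what is new or still open speak of the compounds shown alone.

Going by the values given here, compound 3 `CO[C@H]1O[C@H](COc2ccc(C3CCCCC3)cc2)[C@@H](O)[C@H](O)[C@H]1Oc1ccc(OC2CCCCC2)cc1` holds the lowest of the three numbers so far in a functional assay on HeLa cells (Homo sapiens) for cytotoxicity, read by MTT assay, with a stated time of 48 h (on this read-out lower numbers stand for an effect already at smaller amounts and higher numbers for an effect only at larger amounts of compound), where compound 3 gives 10000 nM as its reading. Compound 1 `CO[C@H]1O[C@H](COc2ccc(OC3CCCCC3)cc2)[C@@H](O)[C@H](O)[C@H]1Oc1ccc(OC2CCCCC2)cc1` gives 14000 nM in this assay, and compound 2 `CO[C@H]1O[C@H](COc2ccc(-c3ccccc3)cc2)[C@@H](O)[C@H](O)[C@H]1Oc1ccc(C(C)C)cc1` gives 19000 nM there; both of these lie within the scatter of compound 3, so no ordering among the three can be claimed. Among the compounds with values here, the only single-change step measured is a 1.4-fold lower number from compound 1 to compound 3 (0.15 log units; within the scatter), and it concerns the aryl ether on the ring carbon of the core, not the one on the oxygen on a saturated carbon.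

Compound 4 `CO[C@H]1O[C@H](COc2cccc(C(C)C)c2)[C@@H](O)[C@H](O)[C@H]1Oc1ccc(OC2CCCCC2)cc1` differs from compound 3 by 3-isopropylphenyl in place of 4-cyclohexylphenyl on an oxygen on a saturated carbon. Within the data shown here, no measured step bears on this side of the core directly; the step from compound 1 to compound 3 is the nearest analogy and was itself within the scatter. Nothing in the three measured compounds points to a step beyond the scatter in this assay in either direction. The step expected from compound 3 to compound 4 is therefore a 1.3-fold higher number from compound 3 to compound 4 (0.11 log units; within the scatter). Compound 4 is estimated at 13000 nM, with an expected range from 5000 nM to 35000 nM.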

Compound 4, half-maximal effective concentration: 28000 nM
Beside the measured number, compound 4's estimate is 2.2-fold (0.33 log units) below it; measured number inside the range.
By their numbers in this assay, from the lowest: compounds 3, 1, 2 and 4 (each within the scatter of the next, the first and the last beyond it).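

Going by these compounds alone, on the oxygen on a saturated carbon, a 2.8-fold higher number from compound 3 to compound 4 (0.45 log units; beyond the scatter) in this assay is the only step beyond the scatter, so the reading on this side of the core does respond to the aryl group, while the one step on the other aryl ether, a 1.4-fold lower number from compound 1 to compound 3 (0.15 log units; within the scatter), stayed within it. The change is modest and joins two differences, since 3-isopropylphenyl has fewer heavy atoms than 4-cyclohexylphenyl and its group also has a different number on the phenyl, and this single pair cannot separate them. Nothing available accounts for the step.

Going by these compounds, how a phenyl carrying an amine or a carboxylic acid would read on this oxygen remains open. Also open, on these data alone, is whether the step would hold with another aryl ether on the other side of the core.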